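Changing the acyl group of compound 1 at the amide carbonyl

The compounds below may be only part of what the source reports. "The series", "measured", "known", "first", "only" and "open" are said of these compounds alone.

Measured so far:
compound 1 `COc1ccc(CN(C(=O)C=C(C)C)c2cc(OC)c(OC)c(OC)c2)cc1O`: 280 nM
compound 2 `COc1cc(NCc2cccc(O)c2)cc(OC)c1OC`: 71300 nM
compound 3 `C/C=C/C(=O)N(Cc1cccc(O)c1)c1cc(OC)c(OC)c(OC)c1`: 14700 nM

Of the compounds shown here, three sharing a trimethoxyphenyl-bearing core have been tested in a functional assay on KYSE-450 cells (Homo sapiens) for inhibition, read by MTT assay, with a stated time of 48 h; on this read-out higher numbers stand for weaker inhibition and lower numbers for stronger inhibition. Compound 1 gives the lowest of the three numbers in this assay; its nearest neighbour is compound 3, and compound 2 stands furthest away. Within the data shown here, the one single-point step among them, a 4.9-fold lower number from compound 2 to compound 3 (0.69 log units; beyond the scatter), shows that placing an acyl group on the ring-bound nitrogen of compound 2 lowers the number by a modest amount. Compound 1 and compound 3 differ in more than one place, so only their two values can be compared: the number for compound 1 is far below that for compound 3.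

Compound 4 `COc1ccc(CN(C(=O)C[Se]C#N)c2cc(OC)c(OC)c(OC)c2)cc1O` is the next compound to be measured in this assay. It differs from compound 1 as follows: a group of 4 heavy atoms (2 carbon, 1 nitrogen, 1 selenium; no ring) in place of a group of 4 heavy atoms (4 carbon; no ring), on a carbonyl carbon. Among the measured compounds shown here, no measured step changes the group on the carbonyl carbon while keeping the amide intact, so the one measured step speaks only indirectly: it confirms that the acylated nitrogen matters, not which acyl group is best. Compound 4 keeps the acylated nitrogen but loses the double bond outside aromatic rings of compound 1. The size and direction of a 4.3-fold higher number from compound 1 to compound 4 (0.63 log units; beyond the scatter) is therefore estimated with little support, and a somewhat higher number is expected for compound 4, around 1200 nM, within a range from 250 nM to 6000 nM.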

Compound 4, half-maximal inhibitory concentration: 280 nM
Beside the measured number, compound 4's estimate is 4.3-fold (0.63 log units) above it; the measured number falls inside the stated range.
By their numbers in this assay, from the lowest: compounds 1 and 4 (each within the scatter of the next); then compound 3; then compound 2.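

Among these compounds, the step on the carbonyl carbon whose other neighbour is the amide-type nitrogen is the first one here that keeps the amide intact and changes only the group attached to it: in this assay, it reads no change at the digits printed from compound 1 to compound 4 (within the scatter) for this exchange. The earlier step showed only what happens when an acyl group is placed on the nitrogen of compound 2, whereas this one shows that, for this pair, 2-methylprop-1-en-1-yl can give way to a group with selenium and a triple bond, with no double bond outside aromatic rings, and the number stays within the scatter. The two compounds therefore show that neither the double bond outside aromatic rings nor an all-carbon group is needed at this place to keep the number of compound 1, though no measurement of any property of either group is available to explain the result.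

Both groups hold the same count of heavy atoms, so the compounds shown do not tell how a methyl group or a longer chain would fare on this carbonyl carbon. They also leave open whether the selenium matters, since a sulfur atom in its place, or an amine or a carboxylic acid on the group, is not among them.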